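A few compounds are considered here, and "the series" means these few. Any claim that something is new, unique, unknown or untested is made for them only; others in the source may bear on it.

Measured in a functional assay on HL-60 cells (Homo sapiens) for inhibition, read by MTT assay, with a stated time of 48 h, tested at 10 uM; a lower number here means less inhibition of growth, a higher number more inhibition of growth at the concentration tested:
- compound 1 `CCN(CC)Cc1c(O)c([C@H]2CCN(C)C[C@H]2O)c2oc(C)cc(=O)c2c1O`: 47%
- compound 2 `CCOC(=O)N1CCN(Cc2c(O)c([C@H]3CCN(C)C[C@H]3O)c3oc(C)cc(=O)c3c2O)CC1`: 16%

Compound 2, at 16%, stands lower of the two in this assay, beyond the scatter from compound 1. Compound 3 `Cc1cc(=O)c2c(O)c(CN(C(C)C)C(C)C)c(O)c([C@H]3CCN(C)C[C@H]3O)c2o1` has diisopropylamino in place of 4-(ethoxycarbonyl)piperazin-1-yl on a saturated chain carbon bound to an aromatic carbon. Among the compounds with values here, one measured step bears on this change: a number 31 percentage points lower from compound 1 to compound 2 (beyond the scatter), a large one, where diethylamino gave way to the same piperazinyl group. Going by these compounds, the entering group, like the diethylamino of compound 1, has no ring, so a large rise, somewhat smaller than that fall, is expected, though diisopropylamino itself is untested. The expected step is a number 24 percentage points higher from compound 2 to compound 3 (beyond the scatter). For compound 3 the estimated value is 40%, within a range of 22% to 58%.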

Compound 3, percent growth inhibition at one concentration: 21%
Compound 3: middle estimate off by 19 percentage points, on the high side; the whole stated range lies above it.
By their numbers in this assay, from the lowest: compounds 2 and 3 (each within the scatter of the next); then compound 1.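

In this assay, replacing the ring-bearing 4-(ethoxycarbonyl)piperazin-1-yl with ringless diisopropylamino gives a step (a number 5 percentage points higher from compound 2 to compound 3 (within the scatter)), so on this saturated chain carbon bound to an aromatic carbon, the absence of a ring does not by itself return the figure of compound 1. Diisopropylamino in place of diethylamino, both ringless amines, gives another step (a number 26 percentage points lower from compound 1 to compound 3 (beyond the scatter)), showing that the change depends on more than a ring. No evidence is available to explain this result. Going by these compounds, it remains open how dimethylamino would behave in this place, and whether a plain piperidine or morpholine ring would match diethylamino or the ethoxycarbonyl piperazine.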